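A few compounds are considered here, and "the series" means these few. Any claim that something is new, unique, unknown or untested is made for them only; others in the source may bear on it.

Compound 1 `CC(C)(C)OC(=O)N1CCC(CCCNc2ccc3c(c2)CCS3(=O)=O)CC1` gives 224 nM.
Compound 2 `CC(C)(C)OC(=O)N1CCC(CCCNc2ccc3c(c2)OCC3=O)CC1` gives 66 nM.
Compound 3 `CC(C)(C)OC(=O)N1CCC(CCCNc2ccc3c(c2)C(=O)NC3)CC1` gives 892 nM.

All three numbers come from a functional assay on CHO-K1 cells for agonist activity at Glucose-dependent insulinotropic receptor (Mus musculus), read by HTRF and cAMP accumulation, with a stated time of 30 min; on this read-out higher numbers stand for an effect only at larger amounts of compound and lower numbers for an effect already at smaller amounts. Compound 2 shows the lowest number of the three, and its gaps to compound 1 and to compound 3 both lie beyond the usual scatter, so within this small set compound 2 is the most potent. Compound 4 `COc1cnc(N2CCC(CCCNc3ccc4c(c3)OCC4=O)CC2)nc1` keeps the shared core of compound 2 and differs in one place: 5-methoxypyrimidin-2-yl in place of tert-butoxycarbonyl on an amine nitrogen in a ring. Going by the values given here, no measured pair shows what such a change does here, so the expectation rests on compound 2 alone. Compound 4 is expected to give about 50 nM, in a range from 10 nM to 250 nM. That estimate means a step of a 1.3-fold lower number from compound 2 to compound 4 (0.12 log units; within the scatter) that is expected to stay close to the scatter, with no clear direction.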

Compound 4, half-maximal effective concentration: 60 nM
Compound 4: the middle estimate sits 1.2-fold (0.08 log units) below what was measured; measured number inside the range.
By their numbers in this assay, from the lowest: compounds 4 and 2 (each within the scatter of the next); then compound 1; then compound 3.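

On the amine nitrogen of the six-membered non-aromatic ring, 5-methoxypyrimidin-2-yl can take the place of tert-butoxycarbonyl: the step of a 1.1-fold lower number from compound 2 to compound 4 (0.04 log units; within the scatter) in this assay stays within the scatter, so the two compounds cannot be told apart. For this pair, a group with one six-membered aromatic ring serves as well as a group with no ring. Nothing shown here explains this match.

As far as these compounds go, it remains open whether a phenyl ring, an acetyl group or a free amine on that nitrogen would give a similar number. From the compounds shown here alone, the same swap on the cores of compound 1 and compound 3 also remains untested here.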